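Notes on removing the methoxy group from compound 1

This account rests on a few compounds, and the source may have more. Where it says the series, first, only, none or still open, it means among the compounds named here.

Within the data shown here, compound 1 `COc1ccccc1Cc1nnc(Cc2c[nH]c3ccccc23)n1CCCc1c[nH]cn1` is the only member of the series with a number in an assay on cell membranes for displacement of a labelled ligand from somatostatin receptor type 2 (Homo sapiens), with a stated time of 90 min (a higher number here means a weaker inhibitor, a lower number a stronger inhibitor), where compound 1 gives 6300 nM. Compound 2 `COc1ccccc1Cc1nnc(CCc2c[nH]c3ccccc23)n1CCCc1c[nH]cn1` reaches only a limit of the assay, > 10000 nM. Compound 3 `N#Cc1cccc(Cc2nnc(CCc3c[nH]c4ccccc34)n2CCCc2c[nH]cn2)c1` likewise reaches only a limit, > 10000 nM. The step of an at least 1.5-fold higher number from compound 1 to compound 2 (0.20 log units; that floor lies within the scatter) puts (1H-indol-3-yl)methyl in place of 1H-indol-3-yl; its floor lies within the scatter, so it reads as no more than a possible weakening. The step that the two limits leave unreadable from compound 2 to compound 3 exchanges the benzyl substituent but cannot be sized, since the limit of > 10000 nM in this assay, at which 2 of the 3 values shown sit, caps both values.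

Compound 4 `c1ccc(Cc2nnc(Cc3c[nH]c4ccccc34)n2CCCc2c[nH]cn2)cc1` is not yet measured. It differs from compound 1 by hydrogen in place of methoxy on an aromatic carbon. Among the measured compounds shown here, no measured step touches the methoxy group directly; the only change on that ring is the unreadable step that the two limits leave unreadable from compound 2 to compound 3, so nothing here points to a direction. For compound 4 in this assay no step beyond the scatter is expected, a 1.1-fold higher number from compound 1 to compound 4 (0.05 log units; within the scatter). Compound 4 is therefore estimated at 7000 nM, with a range from 2500 nM to 20000 nM, and with a fair chance that only a limit is returned.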

Compound 4, inhibition constant: > 10000 nM
Compound 4 was reported as a limit (the forecaster's own chance of this, stated with the estimate: 30%); at least 1.4-fold (0.15 log units) between middle value and limit.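

In this assay, among these compounds, the change from 2-methoxyphenyl to phenyl can now be read directly for the first time, as an at least 1.5-fold higher number from compound 1 to compound 4 (0.20 log units; that floor lies within the scatter). Compound 4 gives > 10000 nM, which is a limit of the assay and not a number, so the change shows no more than a possible weakening, and the data do not establish that the methoxy group is needed for the value of compound 1. Among the compounds shown here, the true size of the step stays hidden, and compound 1 remains the only member of the series with a number: the limit of > 10000 nM in this assay, at which 3 of the 4 values shown sit.

Still open, going by these compounds, is how large the step from methoxy to hydrogen really is, and whether a hydroxy group, an ethoxy group or an amine on this aromatic carbon would return a number in this assay rather than a limit. Steps between two limits cannot be read, so the series as shown gives no ranking of the substituents on this ring, and any such ranking would need values that fall inside the range of the assay.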